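The compounds below may be only part of what the source reports. "The series", "measured", "known", "first", "only" and "open" are said of these compounds alone.

In a functional assay on MCF7 cells (Homo sapiens) for antiproliferative activity, read by CCK-8 assay, with a stated time of 72 h (on this read-out higher numbers stand for weaker inhibition and lower numbers for stronger inhibition), compound 1 `CCc1ccc(C(=O)Nc2cccc(-c3oc4cc(-c5ccc(F)cc5)ccc4c(=O)c3O)c2)cc1` gives 22800 nM, compound 2 `COc1cc(OC)cc(C(=O)Nc2cccc(-c3oc4cc(-c5ccc(F)cc5)ccc4c(=O)c3O)c2)c1` gives 3470 nM, and compound 3 `Cc1cc(C)cc(C(=O)Nc2cccc(-c3oc4cc(-c5ccc(F)cc5)ccc4c(=O)c3O)c2)c1` gives 20400 nM. Among these three numbers compound 3 stands second highest: the step of a 1.1-fold lower number from compound 1 to compound 3 (0.05 log units; within the scatter) lies within the scatter, while the step of a 5.9-fold higher number from compound 2 to compound 3 (0.77 log units; beyond the scatter) lies beyond it, so compound 2 alone is separated from compound 3 on this assay.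

Compound 4 `O=C(Nc1cccc(-c2oc3cc(-c4ccc(F)cc4)ccc3c(=O)c2O)c1)c1ccc(-c2ccccc2)cc1` differs from compound 3 in one place: 4-phenylphenyl in place of 3,5-dimethylphenyl on a carbonyl carbon. The measured steps that bear on this change are both exchanges of the group on the same carbonyl carbon. The step of a 1.1-fold lower number from compound 1 to compound 3 (0.05 log units; within the scatter) shows that moving from one alkyl-bearing phenyl to another leaves the number where it was, whereas the step of a 5.9-fold higher number from compound 2 to compound 3 (0.77 log units; beyond the scatter) shows that only the 3,5-dimethoxyphenyl stands apart. The 4-phenylphenyl of compound 4 carries no methoxy group, so no step beyond the scatter is expected in this assay.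

Compound 4 is therefore estimated at 17000 nM, within 5000 nM to 60000 nM, which means an expected step of a 1.2-fold lower number from compound 3 to compound 4 (0.08 log units; within the scatter).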

Compound 4, half-maximal inhibitory concentration: 38500 nM
Estimate against measurement, compound 4: 2.3-fold (0.36 log units) below; the measured number falls inside the stated range.
By their numbers in this assay, from the lowest: compound 2; then compounds 3, 1 and 4 (each within the scatter of the next).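

In this assay, the 4-phenylphenyl on the carbonyl carbon, with its second aromatic ring, gives a 1.9-fold higher number from compound 3 to compound 4 (0.28 log units; within the scatter) against the 3,5-dimethylphenyl, and phenyl in place of ethyl on the aromatic carbon gives a 1.7-fold higher number from compound 1 to compound 4 (0.23 log units; within the scatter) in the same series, so neither exchange separates these compounds. For the compounds shown here, measured against the 3,5-dimethoxyphenyl, the same group gives an 11-fold higher number from compound 2 to compound 4 (1.05 log units; beyond the scatter) and this widens the gap seen so far, leaving compound 2 as the only compound set apart and the most potent of the four. Nothing available bears on the reason for these numbers.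

From the compounds shown here alone, whether a single methoxy group would keep the number of compound 2 remains open. So does the outcome with a hydroxyl, an amine or a carboxylic acid on this ring, or with a pyridine in place of the phenyl.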